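Side-Chain Exchange on the Shared Core: Compound 3

The source may hold more compounds than are shown below. What is called first, only, known or untested is meant among the compounds shown, and "the series" means these compounds.

- Compound 1 `Cn1ncc(Cl)c1-c1cc(C(=O)N[C@@H]2CN[C@H](CCN3CCC(O)CC3)C[C@H]2c2ccc(Cl)c(Cl)c2)oc1Cl` gives 13700 nM
- Compound 2 `Cn1ncc(Cl)c1-c1cc(C(=O)N[C@@H]2CN[C@H](CC(=O)NCC(O)CO)C[C@H]2c2ccc(Cl)c(Cl)c2)oc1Cl` gives 7090 nM

In a functional assay on HCT-116 cells (Homo sapiens) for antiproliferative activity, read by sulforhodamine B assay, with a stated time of 72 h (on this read-out higher numbers stand for weaker inhibition and lower numbers for stronger inhibition), compound 2 stands at 7090 nM and within the scatter of compound 1. Compound 3 `Cn1ncc(Cl)c1-c1cc(C(=O)N[C@@H]2CN[C@H](CCN3CCCC3)C[C@H]2c2ccc(Cl)c(Cl)c2)oc1Cl` carries (pyrrolidin-1-yl)methyl in place of (2,3-dihydroxypropyl)carbamoyl on a saturated chain carbon bound to a saturated ring carbon. Within the data shown here, the only measured step at this place is a 1.9-fold lower number from compound 1 to compound 2 (0.29 log units; within the scatter), which involves the same (2,3-dihydroxypropyl)carbamoyl and stays within the scatter. The expected result in this assay is a 1.1-fold higher number from compound 2 to compound 3 (0.05 log units; within the scatter), with no step beyond the scatter anticipated. Compound 3 is estimated at 8000 nM, with an expected range of 3000 nM to 20000 nM.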

Compound 3, half-maximal inhibitory concentration: 1940 nM
For compound 3 the middle estimate is 4.1-fold (0.62 log units) above the measured one; measured number below the stated range.
By their numbers in this assay, from the lowest: compound 3; then compounds 2 and 1 (each within the scatter of the next).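

In this assay this position now shows steps beyond the scatter, which the earlier pair did not: (pyrrolidin-1-yl)methyl in place of (2,3-dihydroxypropyl)carbamoyl gives a 3.7-fold lower number from compound 2 to compound 3 (0.56 log units; beyond the scatter). Pyrrolidin-1-yl in place of 4-hydroxypiperidin-1-yl gives a 7.1-fold lower number from compound 1 to compound 3 (0.85 log units; beyond the scatter), so exchanging one ring for the other on the same chain is enough to move the number beyond the scatter. Nothing available here bears on the cause of either step.

The two rings differ both in size and in the hydroxy group, and the compounds shown do not separate these. Unsubstituted piperidin-1-yl or dimethylamino on the same chain would bear on this.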